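Terminal vinyl on the deacetylated thioglycoside amides

The source may report more compounds than this note shows. Statements on the series, on what has been measured and on what is new or still open speak of the compounds shown alone.

Compound 1 `CCCCCCCCCCCC(=O)Nc1nnc(S[C@@H]2O[C@H](COC(C)=O)[C@H](OC(C)=O)[C@H](OC(C)=O)[C@H]2OC(C)=O)s1` carries the fully acetylated sugar and a saturated chain; in a functional assay on HeLa cells (Homo sapiens) for cytotoxicity, read by MTT assay, with a stated time of 24 h (a lower number here means a stronger inhibitor, a higher number a weaker inhibitor), compound 1 gives 51900 nM. Compound 2 `C=CCCCCCCCCC(=O)Nc1nnc(S[C@@H]2O[C@H](COC(C)=O)[C@H](OC(C)=O)[C@H](OC(C)=O)[C@H]2OC(C)=O)s1` keeps that core, and in this assay compound 2 gives 77700 nM. The change between them is vinyl in place of propyl on a saturated chain carbon, eight bonds along the chain from a carbonyl carbon and it produced a 1.5-fold higher number from compound 1 to compound 2 (0.18 log units; within the scatter), so the two values are not separable.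

Compound 3 `CCCCCCCCCCCC(=O)Nc1nnc(S[C@@H]2O[C@H](CO)[C@H](O)[C@H](O)[C@H]2O)s1` is the free-hydroxyl counterpart of compound 1; in this assay compound 3 gives 8700 nM, the lowest of the three numbers and beyond the scatter from both acetylated compounds. The difference between the core of compound 3 and the core of compound 1 is not broken down here.

Compound 4 `C=CCCCCCCCCC(=O)Nc1nnc(S[C@@H]2O[C@H](CO)[C@H](O)[C@H](O)[C@H]2O)s1` is not yet measured. It differs from compound 3 by vinyl in place of propyl on a saturated chain carbon, eight bonds along the chain from a carbonyl carbon, the same change as from compound 1 to compound 2, at the same place.

For compound 4 the expected step is a 1.4-fold higher number from compound 3 to compound 4 (0.16 log units; within the scatter), because the earlier step of a 1.5-fold higher number from compound 1 to compound 2 (0.18 log units; within the scatter) lay within the scatter and nothing in the free-hydroxyl core is known to alter that. Compound 4 is therefore estimated at 12500 nM in this assay, with a range of 5000 nM to 32000 nM.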

Compound 4, half-maximal inhibitory concentration: 58300 nM
Compound 4: the middle estimate sits 4.7-fold (0.67 log units) below what was measured; measured number outside the range, above it.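

In this assay, vinyl in place of propyl gives a 6.7-fold higher number from compound 3 to compound 4 (0.83 log units; beyond the scatter), so the size of the step does not carry from the acetylated core to the free-hydroxyl core: the same change on two cores in this assay, a 1.5-fold higher number (0.18 log units; within the scatter) from compound 1 to compound 2 and a 6.7-fold higher number (0.83 log units; beyond the scatter) from compound 3 to compound 4, 4.5-fold (0.65 log units) apart, beyond the scatter of two such steps. The change can therefore not be treated as a fixed increment in this series: a step within the scatter on one core gave no reliable guide to the step on the other. This rests on one pair of compounds per core in one assay, and it shows neither the cause of the gap nor whether other changes to the chain depend on the core in the same way.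

The compounds shown leave open whether a terminal alkyne, a terminal carboxylic acid or a longer chain would also give steps that differ between the two cores. Also open, from the compounds shown here alone, is whether a partly acetylated sugar would give a step closer to that on the acetylated core or to that on the free-hydroxyl core.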